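A Chloro Stand-in for the Piperazine Group

This account rests on a few compounds, and the source may have more. Where it says the series, first, only, none or still open, it means among the compounds named here.

Compound 1 `CN(C)c1ccc(-c2cc(C(=O)N3CCC4(CC3)CC(=O)c3nn(C(C)(C)C)cc3O4)c3ccccc3n2)cc1`: 1150 nM
Compound 2 `CC(C)(C)n1cc2c(n1)C(=O)CC1(CCN(C(=O)c3cc(N4CCNCC4)nc4ccccc34)CC1)O2`: > 10000 nM

In a functional assay on A549 cells (Homo sapiens) for inhibition, read by MTT assay, with a stated time of 72 h (a lower number here means a stronger inhibitor, a higher number a weaker inhibitor), compound 1 gives 1150 nM. Compound 2 reaches only a limit, > 10000 nM, in this assay, (the limit of > 10000 nM in this assay, at which 1 of the 2 values shown sits). Within the data shown here, the single measured step, an at least 8.6-fold higher number from compound 1 to compound 2 (0.93 log units; beyond the scatter), concerns the same aromatic carbon but a different pair of groups, so it offers no direct guide. Compound 3 `CC(C)(C)n1cc2c(n1)C(=O)CC1(CCN(C(=O)c3cc(Cl)nc4ccccc34)CC1)O2` differs from compound 2 by chloro in place of piperazin-1-yl on an aromatic carbon, the chloro sitting next to the ring nitrogen. With compound 2 known only as a limit, the step cannot be sized, and compound 3 is expected near 8000 nM, between 2000 nM and 30000 nM. The estimated step is an at least 1.2-fold lower number from compound 2 to compound 3 (0.09 log units; that floor lies within the scatter).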

Compound 3, half-maximal inhibitory concentration: 7170 nM
Beside the measured number, compound 3's estimate is 1.1-fold (0.05 log units) above it; measured number inside the range.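

Compound 3 gives this position a measured number with chloro, where the piperazin-1-yl of compound 2 stands only as a limit: the limit of > 10000 nM in this assay, at which 1 of the 3 values shown sits. The change from piperazin-1-yl to chloro reads only as an at least 1.3-fold lower number from compound 2 to compound 3 (0.14 log units; that floor lies within the scatter) and so does not rank the two groups. Chloro still falls short of 4-(dimethylamino)phenyl, with a 6.2-fold higher number from compound 1 to compound 3 (0.79 log units; beyond the scatter), which makes the aryl group of compound 1 the only one here separated from chloro by a measured step.

As far as these compounds go, whether a plain phenyl, without the dimethylamino group, or a morpholine ring on this carbon would come nearer to compound 1 remains open.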